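Adding a second methoxy: compound 2 to compound 4

This account rests on a few compounds, and the source may have more. Where it says the series, first, only, none or still open, it means among the compounds named here.

Of the compounds shown here, three have numbers so far in a functional assay on MOLT-4 cells (Homo sapiens) for antiproliferative activity, with a stated time of 48 h; on this read-out higher numbers stand for weaker inhibition and lower numbers for stronger inhibition: compound 1 (`C=C(Br)C(=O)Nc1ccc(C(=O)/C=C/c2cc(OC)cc(OC)c2)cc1`) gives 1500 nM, compound 2 (`COc1cccc(/C=C/C(=O)c2ccc(N)cc2)c1`) gives 21000 nM and compound 3 (`COc1cccc(/C=C/C(=O)c2ccc(N)cc2)c1OC`) gives 8500 nM. Compound 2 therefore carries the highest number of the three. Compound 4 (`COc1cc(/C=C/C(=O)c2ccc(N)cc2)cc(OC)c1`) has not been measured. It departs from compound 2 by one change: methoxy in place of hydrogen on an aromatic carbon, a methoxy in place of hydrogen on an aromatic carbon, meta to a large group and meta to a methoxy group.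

Among the measured compounds shown here, the only measured step of this kind is a 2.5-fold lower number from compound 2 to compound 3 (0.39 log units; beyond the scatter), a modest one from the same replacement at another carbon of the ring. For the measured compounds named here, compound 1 has the methoxy groups of compound 4 but differs elsewhere, so it gives no step for this change. One precedent leaves the size loose, but a similar modest move to a lower number is expected. The expected step is a 2.3-fold lower number from compound 2 to compound 4 (0.37 log units; beyond the scatter). The estimate for compound 4 is 9000 nM, with an expected range of 3500 nM to 20000 nM.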

Compound 4, half-maximal inhibitory concentration: 7500 nM
Compound 4: the middle estimate sits 1.2-fold (0.08 log units) above what was measured, within the range that was stated.
By their numbers in this assay, from the lowest: compound 1; then compounds 4 and 3 (each within the scatter of the next); then compound 2.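

In this assay methoxy in place of hydrogen on the aromatic carbon meta to a large group and meta to a methoxy group gives a 2.8-fold lower number from compound 2 to compound 4 (0.45 log units; beyond the scatter) and this is a second carbon of the ring where the change brings a modest move to a lower number. Compound 3 and compound 4 stand within the scatter of each other, so the compounds shown do not separate these two placements. Hydrogen in place of (1-bromoethenyl)carbonyl on the nitrogen gives a 5.0-fold higher number from compound 1 to compound 4 (0.70 log units; beyond the scatter) as the first step read at that nitrogen, with the methoxy groups unchanged.

Open, on these data alone, is whether a hydroxyl or a fluorine on this carbon, or an acetyl on the nitrogen, would move the number the same way. Nothing at hand says why either step takes its size.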